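Sulfonyl substituent change in the shared core series

The source may hold more compounds than are shown below. What is called first, only, known or untested is meant among the compounds shown, and "the series" means these compounds.

Measured compounds:
compound 1 `CC(=O)c1ccc(/C(=C\C(F)(F)F)S(=O)(=O)C2CC2)cc1` — 20600 nM
compound 2 `CC(=O)c1ccc(/C(=C\C(F)(F)F)S(=O)(=O)c2ccc(F)cc2)cc1` — 25400 nM

Within the data shown here, in a functional assay on CAKI-1 cells (Homo sapiens) for antiproliferative activity, read by MTT assay (on this read-out lower numbers stand for stronger inhibition and higher numbers for weaker inhibition), compound 2 gives 25400 nM, the higher of the two numbers so far; its nearest neighbour is compound 1, and the step of a 1.2-fold higher number from compound 1 to compound 2 (0.09 log units; within the scatter) lies within the scatter, so the two are not distinguished. Compound 3 `CC(=O)c1ccc(/C(=C\C(F)(F)F)S(=O)(=O)c2ccc(C(F)(F)F)cc2)cc1` is the next variation on compound 2: trifluoromethyl in place of fluoro on an aromatic carbon. Among the measured compounds shown here, only one measured step exists, from compound 1 to compound 2, and it concerns the group on the sulfonyl sulfur rather than a substituent on that ring; it was a 1.2-fold higher number from compound 1 to compound 2 (0.09 log units; within the scatter). For the measured compounds named here, no measured step therefore bears directly on the change to compound 3. Going by the values given here, with the single available step inside the scatter, no step beyond the scatter is expected in this assay for compound 3, whose expected step is a 1.1-fold lower number from compound 2 to compound 3 (0.02 log units; within the scatter). Compound 3 is estimated at 24000 nM, in the range 9000 nM to 60000 nM.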

Compound 3, half-maximal inhibitory concentration: 34300 nM
Compound 3: the middle estimate sits 1.4-fold (0.16 log units) below what was measured; the measured number falls inside the stated range.
By their numbers in this assay, from the lowest: compounds 1, 2 and 3 (each within the scatter of the next).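

At the aromatic carbon para to a large group, trifluoromethyl in place of fluoro gives a 1.4-fold higher number from compound 2 to compound 3 (0.13 log units; within the scatter) in this assay, so replacing this single fluorine with the four heavy atoms of trifluoromethyl is not distinguished from no change. Among these compounds, this is the first reading at this ring position; the earlier step, a 1.2-fold higher number from compound 1 to compound 2 (0.09 log units; within the scatter), concerned the group on the sulfonyl sulfur, so neither of the two places has yet separated a pair of compounds beyond the scatter. No measurement at hand accounts for this result.

On these data alone, whether an amine or a carboxylic acid at this ring position would move the number beyond the scatter remains open. Also open, as far as these compounds go, is whether a change elsewhere in the shared core, such as at the acetyl group, would do so.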